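Amino in place of chloro: expected tolerance of compound 4

A few compounds are considered here, and "the series" means these few. Any claim that something is new, unique, unknown or untested is made for them only; others in the source may bear on it.

Compound 1 `ClCc1ccccc1Cn1cnc2c(Cl)nc(Cl)nc21` carries two chloro groups on the shared core and a chloromethyl on its benzyl arm; in a functional assay on HOP-92 cells (Homo sapiens) for cytotoxicity, read by sulforhodamine B assay, with a stated time of 48 h (a lower number here means that less compound is tolerated, a higher number that more compound is tolerated), compound 1 gives "not determined" (no result reported), so no number places it among its neighbours. Compound 3 `ClCc1cccc(Cn2cnc3nc(Cl)nc(Cl)c32)c1` gives 5240 nM in this assay. Compound 2 `Nc1nc(Cl)c2ncn(Cc3ccc(CCl)cc3)c2n1` reaches only a limit of this assay, > 100000 nM. Compound 4 `Nc1nc(Cl)c2ncn(Cc3ccccc3CCl)c2n1` differs from compound 1 by amino in place of chloro on an aromatic carbon. Within the data shown here, no measured pair shows this change; the only amino-bearing compound, compound 2, sits at the limit of > 100000 nM in this assay, at which 1 of the 3 values shown sits, so a step toward a more tolerated compound, beyond the scatter, is expected. Compound 4 is expected to give about 100000 nM, within 20000 nM to 300000 nM, with a limit the likely outcome.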

Compound 4, concentration lethal to 50% of the cells: > 100000 nM
Compound 4: no number, only a limit (the forecaster's own chance of this, stated with the estimate: 60%); the middle value sits exactly at the limit.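

Among these compounds, compound 1 has no number and compound 4 gives only a limit, so no step between them can be read. Whether amino in place of chloro shifts tolerance at all stays open, and the amino-bearing compound 2 and compound 4 rest at the same mark: the limit of > 100000 nM in this assay, at which 2 of the 4 values shown sit.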